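Swapping ethyl for cyclopropyl on the ring nitrogen

A few compounds are considered here, and "the series" means these few. Any claim that something is new, unique, unknown or untested is made for them only; others in the source may bear on it.

Measured compounds:
- compound 1, `Cn1c(C(F)(F)F)ccc(NCc2cc3cc(Cl)ccc3[nH]c2=O)c1=O`: < 100 nM
- compound 2, `C[C@H](Nc1ccc(C#N)n(C)c1=O)c1cc2cc(Cl)c(OCc3ccccn3)cc2[nH]c1=O`: 2500 nM
- compound 3, `CCn1cccc(NCc2cc3cc(Cl)ccc3[nH]c2=O)c1=O`: 10000 nM

These three compounds share a core and were tested in a physicochemical assay for solubility; a higher number here means a more soluble compound, a lower number a less soluble compound. For compound 1 the result is a limit of the assay, < 100 nM, and not a number, as noted in the limit of < 100 nM in this assay, at which 1 of the 3 values shown sits. Compound 2 gives 2500 nM in this assay. Compound 3 stands highest of the two numbers with 10000 nM, and compound 2 sits a clear step below it, beyond the usual scatter.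

The next compound, compound 4, `O=c1[nH]c2ccc(Cl)cc2cc1CNc1cccn(C2CC2)c1=O`, has not yet been measured. It differs from compound 3 in one place: cyclopropyl in place of ethyl on an aromatic nitrogen. The three-membered ring replaces a short chain on the aromatic nitrogen, and nothing else moves.

For the measured compounds named here, no measured pair shows this exact change, so only a cautious expectation can be drawn. A step from compound 3 to compound 4 of a 1.7-fold lower number from compound 3 to compound 4 (0.22 log units; within the scatter) is expected, a modest drop that may not rise beyond the scatter. Compound 4 is therefore estimated at 6000 nM in this assay, with a likely range from 2000 nM to 15000 nM.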

Compound 4, solubility: 56000 nM
For compound 4 the middle estimate is 9.3-fold (0.97 log units) below the measured one, and the stated range ends below it.
By their numbers in this assay, from the lowest: compound 2; then compound 3; then compound 4. At a limit, below all of these: compound 1.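

In this assay, for the compounds shown here, the change on the aromatic nitrogen gives a 5.6-fold higher number from compound 3 to compound 4 (0.75 log units; beyond the scatter), and it is the first reading of a single change here, since the earlier compounds offered no pair differing in one place. It shows that this nitrogen is a position where the read-out responds to a small carbon group. Ethyl has 2 heavy atoms and cyclopropyl has 3, neither group has hydrogen-bond donors or acceptors, and nothing else in the molecule moves.

Nothing measured here bears on why the step runs this way. A propyl or isopropyl group on the same nitrogen would help to tell the effect of the closed ring from that of the size of the group, and this single pair cannot say whether the step would hold with other substituents on the shared core.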